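Removing the Trifluoroacetyl Group from a Piperidine Nitrogen

A few compounds are considered here, and "the series" means these few. Any claim that something is new, unique, unknown or untested is made for them only; others in the source may bear on it.

Measured compounds:
compound 1 `O=C1CCC(c2ccccn2)(C2CCN(Cc3ccc(Br)cc3)CC2)C(=O)N1` — 500 nM
compound 2 `O=C(N1CCCC(c2ccccc2)(C2CCN(Cc3ccc(Br)cc3)CC2)C1)C(F)(F)F` — 690 nM

In a functional assay on CHO cells for antagonist activity at C-X-C chemokine receptor type 3 (Homo sapiens), read by GTPgammaS binding, with a stated time of 30 min (on this read-out higher numbers stand for weaker inhibition and lower numbers for stronger inhibition), compound 2 gives 690 nM, the higher of the two numbers, with compound 1 the nearest at 500 nM; the two lie within the scatter of each other. Compound 3 `Brc1ccc(CN2CCC(C3(c4ccccc4)CCCNC3)CC2)cc1` differs from compound 2 by hydrogen in place of (trifluoromethyl)carbonyl on an amine nitrogen in a ring, leaving a free amine nitrogen in the ring. For the measured compounds named here, no measured step of this kind is known, so the direction is uncertain; a modest weakening beyond the scatter is expected, with the step of a 2.2-fold higher number from compound 2 to compound 3 (0.34 log units; beyond the scatter). Compound 3 is estimated at 1500 nM, within 300 nM to 8000 nM.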

Compound 3, half-maximal inhibitory concentration: > 10000 nM
Compound 3: a limit, no number; the forecaster's own chance of this, stated with the estimate: 10%; middle value at least 6.6-fold (0.82 log units) from the limit.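

In this assay, for the compounds shown here, replacing the (trifluoromethyl)carbonyl on the amine nitrogen in the ring with hydrogen gives an at least 14-fold higher number from compound 2 to compound 3 (1.16 log units; beyond the scatter), the first single-place step in this set. On this nitrogen, then, the group cannot be dropped without a large loss of inhibition. Compound 3 sits at a limit of the assay, not at a number, so the full size of the step stays unknown: the limit of > 10000 nM in this assay, at which 1 of the 3 values shown sits.

The compounds shown leave open whether an acetyl group, a methanesulfonyl group or a methyl group on this nitrogen would hold the inhibition seen with compound 2. They also leave open whether the carbonyl or the trifluoromethyl part matters more.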